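The source may report more compounds than this note shows. Statements on the series, on what has been measured and on what is new or still open speak of the compounds shown alone.

In a functional assay on A549 cells (Homo sapiens) for cytotoxicity, read by MTT assay, with a stated time of 72 h (on this read-out higher numbers stand for weaker inhibition and lower numbers for stronger inhibition), the three measured compounds stand as follows.

Compound 1, `CNC(=O)c1cc(Oc2ccc(C(=O)/C=C/c3ccc(C#N)cc3)cc2)ccn1`, gives 26400 nM.
Compound 2, `CNC(=O)c1cc(Oc2ccc(C(=O)/C=C/c3ccc(Cl)cc3Cl)cc2)ccn1`, gives 9460 nM.
Compound 3, `CNC(=O)c1cc(Oc2ccc(C(=O)/C=C/c3ccc(F)cc3)cc2)ccn1`, gives 18600 nM.

Compound 3 holds the second highest of the three numbers, and neither of its neighbours is separated from it by more than the usual scatter: the step of a 1.4-fold lower number from compound 1 to compound 3 (0.15 log units; within the scatter) is within the scatter, and so is the step of a 2.0-fold higher number from compound 2 to compound 3 (0.29 log units; within the scatter). Going by the values given here, the only step that goes beyond the scatter is a 2.8-fold lower number from compound 1 to compound 2 (0.45 log units; beyond the scatter), and even that is modest.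

Compound 4, `CNC(=O)c1cc(Oc2ccc(C(=O)/C=C/c3ccc(OC)cc3)cc2)ccn1`, differs from compound 3 in one place: methoxy in place of fluoro on an aromatic carbon. Of the measured steps, the one that bears most directly on this change is a 1.4-fold lower number from compound 1 to compound 3 (0.15 log units; within the scatter), since it too exchanges one group on that aromatic carbon and leaves the rest of the shared core untouched; it stayed within the scatter. The two steps that swap the whole ring, a 2.8-fold lower number from compound 1 to compound 2 (0.45 log units; beyond the scatter) and a 2.0-fold higher number from compound 2 to compound 3 (0.29 log units; within the scatter), are no larger than modest. The expectation for compound 4 is therefore a step of no more than the scatter, a 1.1-fold lower number from compound 3 to compound 4 (0.04 log units; within the scatter). Compound 4 is estimated at 17000 nM, with a range from 7000 nM to 40000 nM.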

Compound 4, half-maximal inhibitory concentration: > 50000 nM
Compound 4 ended at the assay's limit; the forecaster's own chance of this, stated with the estimate: 5%; at least 2.9-fold (0.46 log units) between middle value and limit.
By their numbers in this assay, from the lowest: compounds 2, 3 and 1 (each within the scatter of the next, the first and the last beyond it). At a limit, above all of these: compound 4.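

In this assay compound 4 gives > 50000 nM, which is a limit of the assay and not a number. Going by these compounds alone, on this aromatic carbon, para to a large group, the swap of fluoro for methoxy gives the first single-group exchange to go beyond the scatter, an at least 2.6-fold higher number from compound 3 to compound 4 (0.42 log units; beyond the scatter), whereas the earlier exchange of cyano for fluoro at the same place had stayed within it. Within the data shown here, the whole-ring comparison gives the widest separation in the set, an at least 5.2-fold higher number from compound 2 to compound 4 (0.72 log units; beyond the scatter), while the exchange of cyano for methoxy, an at least 1.8-fold higher number from compound 1 to compound 4 (0.27 log units; that floor lies within the scatter), does not by itself separate the two compounds, so the position is not indifferent to its substituent, though only the step from fluoro to methoxy shows this clearly.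

Going by these compounds, how far compound 4 lies past the limit remains unknown, so the true size of all three steps is open. The compounds shown also cannot tell whether the loss belongs to methoxy alone or would extend to other groups on that carbon, such as a hydroxyl, an ethoxy group or an amine.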